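The compounds below may be only part of what the source reports. "The series", "measured", "known", "first", "only" and "open" are said of these compounds alone.

Three compounds share a core in which a cyanoguanidine links a pyridine ring to an alkyl group on a double-bonded nitrogen. Compound 1 `CC(C)C/N=C(\NC#N)Nc1cccnc1` carries an isobutyl group and, in a functional assay on the whole organism (blood, strain Wistar-Okamoto) with Rattus norvegicus as the target, with a stated time of 5 days (on this read-out lower numbers stand for an effect already at smaller amounts and higher numbers for an effect only at larger amounts of compound), compound 1 gives 20 mg/kg. Compound 2 `CC(/N=C(/NC#N)Nc1cccnc1)C(C)(C)C` carries a larger alkyl group and a pyridine attached at the same position as in compound 1; in this assay compound 2 gives 1 mg/kg. Compound 3 `CC(C)(C)C/N=C(\NC#N)Nc1ccncc1` carries a neopentyl group and a pyridine attached at a different position; in this assay compound 3 gives 5 mg/kg.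

Among the three numbers, compound 3 stands second highest: compound 1 sits above it by a step that is beyond the usual scatter, and compound 2 sits below it by a step that is also beyond the scatter. So compound 3 lies between the two, closer to compound 1.

Compound 4 `CCC(/N=C(\NC#N)Nc1ccncc1)C(C)C` keeps the core and the pyridine of compound 3 and differs only in the alkyl group: 1-isopropylpropyl in place of neopentyl on a double-bonded nitrogen. Among the compounds with values here, no pair of measured compounds differs in exactly this way, so the step has to be estimated. The nearest guide is compound 2, whose value of 1 mg/kg pairs a larger alkyl group with a low dose. On that basis compound 4 is expected to need a somewhat smaller dose than compound 3, a step of a 2.5-fold lower number from compound 3 to compound 4 (0.40 log units; beyond the scatter), estimated at 2 mg/kg with a likely range from 0.5 mg/kg to 8 mg/kg.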

Compound 4, minimum effective dose: 5 mg/kg
The estimate for compound 4 lay 2.5-fold (0.40 log units) below the measured number; the range from low to high includes it.
By their numbers in this assay, from the lowest: compound 2; then compounds 3 and 4 (each within the scatter of the next); then compound 1.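

In this assay, replacing neopentyl with 1-isopropylpropyl on a double-bonded nitrogen gives no change at the digits printed from compound 3 to compound 4 (within the scatter). Within the data shown here, this is the first pair in the set that differs in one place only, and it shows that, with the rest of the molecule held fixed, this position accepts a differently branched alkyl group of 6 heavy atoms in place of one of 5 without a shift beyond the usual scatter. No measured information here explains why the dose stays level.

Going by these compounds, one pair cannot show how far this tolerance extends, so it remains open whether a longer chain such as n-octyl, a cyclohexyl ring or a chain ending in an amine would leave the minimum effective dose equally unchanged. On these data alone, it also remains open whether the same exchange of alkyl groups would be just as silent with the pyridine attached as it is in compound 1, since the pair at hand covers only the attachment found in compound 3.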